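This account rests on a few compounds, and the source may have more. Where it says the series, first, only, none or still open, it means among the compounds named here.

Measured so far:
- compound 1, `COc1c(OCCCCN2CCNCC2)cc(O)c2c(=O)cc(-c3ccccc3)oc12`: in a functional assay on A549 cells (Homo sapiens) for cytotoxicity, read by MTT assay, with a stated time of 48 h (on this read-out lower numbers stand for stronger inhibition and higher numbers for weaker inhibition), compound 1 gives 1740 nM
- compound 2, `CN(C)CCCCOc1c(O)cc(O)c2c(=O)cc(-c3ccccc3)oc12`: compound 2 reports > 100000 nM, a limit of the assay and not a number

Compound 1 holds the only number shown in this assay; the one other entry is a limit. The limit for compound 2 is the limit of > 100000 nM in this assay, at which 1 of the 2 values shown sits. Going by the values given here, compound 2 differs from compound 1 in more than one place, so no single step between them is drawn; the two values show only that compound 1 has a measured number where compound 2 has a limit.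

Compound 3, `COc1c(OCCCN2CCNCC2)cc(O)c2c(=O)cc(-c3ccccc3)oc12`, remains to be measured in this assay. It differs from compound 1 by piperazin-1-yl in place of (piperazin-1-yl)methyl on a saturated chain carbon, three bonds along the chain from an oxygen on an aromatic ring. Read one bond further out, the same change is 4-(piperazin-1-yl)butyl to 3-(piperazin-1-yl)propyl. Among the compounds with values here, no measured step of this kind exists. A change confined to one carbon of the chain is expected to move this assay little, in either direction, and not clearly beyond the scatter. Compound 3 is estimated at 2500 nM, with a range of 800 nM to 8000 nM. The step this estimate implies, a 1.4-fold higher number from compound 1 to compound 3 (0.16 log units; within the scatter), is expected to remain within the usual scatter.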

Compound 3, half-maximal inhibitory concentration: 10100 nM
Compound 3: the middle estimate sits 4.0-fold (0.61 log units) below what was measured, and the stated range ends below it.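

In this assay, going by these compounds alone, the change from 4-(piperazin-1-yl)butyl to 3-(piperazin-1-yl)propyl gives a 5.8-fold higher number from compound 1 to compound 3 (0.76 log units; beyond the scatter), the first readable step. This saturated chain position, three bonds along the chain from an oxygen on an aromatic ring, is therefore not silent in this cell read-out, and of the two chains compared with the rest of the structure held constant, the 4-(piperazin-1-yl)butyl chain of compound 1 carries the lower number. Nothing shown accounts for the size of this step, and it cannot be assigned to any property of the chain.

Going by these compounds, with a single step at this position, no trend with chain length can be claimed, and it remains open whether a shorter 2-(piperazin-1-yl)ethyl chain would raise the number further or a longer 5-(piperazin-1-yl)pentyl chain would lower it. Also open, on these data alone, is how much of the read-out depends on the piperazine itself, a question that a morpholine or a 4-methylpiperazine on the 4-carbon butyl chain of compound 1 would address directly.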